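From Nitro to Dimethylamino: An Expected Whole-Animal Inhibition

A few compounds are considered here, and "the series" means these few. Any claim that something is new, unique, unknown or untested is made for them only; others in the source may bear on it.

Measured compounds:
compound 1 `O=C(/C=C/C1=Cc2ccccc2OC1)c1ccc(F)cc1` — 65.6%
compound 2 `O=C(/C=C/C1=Cc2ccccc2OC1)c1ccc(Br)cc1` — 66%
compound 3 `O=C(/C=C/C1=Cc2ccccc2OC1)c1ccc([N+](=O)[O-])cc1` — 50.8%

Three compounds sharing one core, differing only in the group on one aromatic carbon, were tested in a functional assay on the whole organism for inhibition, with Mus musculus as the target, with a stated time of 1 h, at a dose of 30 mg/kg by the intraperitoneal route; on this read-out lower numbers stand for less inhibition and higher numbers for more inhibition at the one dose given (going by the name of the read-out). Compound 1 with a fluoro group and compound 2 with a bromo group sit close together: the step of a number 0.4 percentage points higher from compound 1 to compound 2 (within the scatter) lies within the scatter, so no order between them can be claimed. Compound 3, carrying a nitro group, stands lowest of the three measured numbers. The step of a number 14.8 percentage points lower from compound 1 to compound 3 (beyond the scatter) and the step of a number 15.2 percentage points lower from compound 2 to compound 3 (beyond the scatter) both lie beyond the scatter, each a modest drop.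

Compound 4 `CN(C)c1ccc(C(=O)/C=C/C2=Cc3ccccc3OC2)cc1` differs from compound 3 in one place: dimethylamino in place of nitro on an aromatic carbon. Within the data shown here, no measured step involves a dimethylamino group, so none bears directly on this change. Among the measured compounds shown here, the only steps that reach compound 3 show that exchanging a halogen for nitro lowered inhibition modestly; they do not say what a third kind of group at the same aromatic carbon will do. The expectation is therefore a number near the middle of the measured range, with a step of a number 7.2 percentage points higher from compound 3 to compound 4 (within the scatter) that is expected to stay within the scatter. Compound 4 is estimated to give 58% in this assay, with a range from 40% to 75%.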

Compound 4, a percentage reported as inhibition, in the whole organism at one dose (the size of the read-out at that dose, not a potency): 57.3%
Compound 4: the middle estimate sits 0.7 percentage points above what was measured; measured number inside the range.
By their numbers in this assay, from the lowest: compounds 3, 4, 1 and 2 (each within the scatter of the next, the first and the last beyond it).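

In this assay, putting dimethylamino in place of nitro gives a number 6.5 percentage points higher from compound 3 to compound 4 (within the scatter) and so cannot be told apart from no change. The same holds on the halogen side, where replacing bromo gives a number 8.7 percentage points lower from compound 2 to compound 4 (within the scatter) and replacing fluoro gives a number 8.3 percentage points lower from compound 1 to compound 4 (within the scatter) even though compound 3 stands apart from both halogen compounds by steps beyond the scatter. This aromatic carbon, on the ring that also carries the carbonyl, therefore holds a group with carbons on its nitrogen and no oxygen, and compound 4 cannot be separated from any of the other three compounds in this whole-animal test. No measurement at hand explains how these groups compare.

The compounds shown leave open what an amino group, a methoxy group or a carboxylic acid would give on this same aromatic carbon, and whether longer chains on the nitrogen, as in diethylamino, would stay close to compound 4. As far as these compounds go, with one dose and one time point, it also remains open whether the compounds would separate more clearly across a range of doses.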